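Chloro added to the core of compound 1

This account rests on a few compounds, and the source may have more. Where it says the series, first, only, none or still open, it means among the compounds named here.

Measured so far:
compound 1, `ClCc1ccc(Cn2cnc3c(Cl)ncnc32)cc1`, 3460 nM
compound 2, `ClCc1ccccc1Cn1cnc2c(Cl)nc(Cl)nc21`, 3380 nM
compound 3, `ClCc1cccc(Cn2cnc3ncnc(Cl)c32)c1`, 19100 nM

In a functional assay on SF-295 cells (Homo sapiens) for cytotoxicity, read by sulforhodamine B assay, with a stated time of 48 h (a higher number here means a weaker inhibitor of growth, a lower number a stronger inhibitor of growth), compound 1 stands second highest of the three. Its nearest neighbour is compound 2, whose number lies within the scatter of that of compound 1; the furthest is compound 3, whose number lies beyond the scatter above it. Compound 4, `ClCc1ccc(Cn2cnc3c(Cl)nc(Cl)nc32)cc1`, is not yet measured. It differs from compound 1 by chloro in place of hydrogen on an aromatic carbon. For the measured compounds named here, no step between measured compounds isolates this change. Compound 2 already carries two chloro groups on the core and in this assay compound 2 gives 3380 nM, close to compound 1, so no step beyond the scatter is expected for compound 4, a 1.2-fold lower number from compound 1 to compound 4 (0.06 log units; within the scatter). Compound 4 is estimated at 3000 nM, range 1200 nM to 8000 nM.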

Compound 4, concentration for total growth inhibition: 19500 nM
Compound 4: middle estimate off by 6.5-fold (0.81 log units), on the low side; measured number outside the range, above it.
By their numbers in this assay, from the lowest: compounds 2 and 1 (each within the scatter of the next); then compounds 3 and 4 (each within the scatter of the next).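

In this assay, chloro in place of hydrogen on the aromatic carbon between two ring nitrogen atoms is not a silent change: it gives a 5.6-fold higher number from compound 1 to compound 4 (0.75 log units; beyond the scatter) and so a weaker inhibitor of growth. Compound 2 gives 3380 nM and compound 4 gives 19500 nM with the same two chloro groups on the core, so these groups alone do not set the number. No measurement on hand explains the step.

As far as these compounds go, whether an amine or a methoxy group at this position would give a number nearer to that of compound 1 remains open.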